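The compounds below may be only part of what the source reports. "The series", "measured", "known", "first", "only" and "open" are said of these compounds alone.

Measured compounds:
compound 1 `O=C1c2c[n+]([O-])c3ccccc3c2C(=O)c2c1c1ccccc1n2CCCCN1CCCCC1`, 610 nM
compound 2 `CN(C)CCCCCn1c2c(c3ccccc31)C(=O)c1c[n+]([O-])c3ccccc3c1C2=O`, 240 nM
compound 3 `CN1CCN(CCCCn2c3c(c4ccccc42)C(=O)c2c[n+]([O-])c4ccccc4c2C3=O)CC1`, 80 nM

In a toxicity assay on L02 cells (Homo sapiens) for cytotoxicity, read by MTT assay, with a stated time of 72 h (on this read-out lower numbers stand for stronger inhibition and higher numbers for weaker inhibition), compound 3 gives the lowest number of the three, with steps beyond the scatter to both others: a 7.6-fold lower number from compound 1 to compound 3 (0.88 log units; beyond the scatter) and a 3.0-fold lower number from compound 2 to compound 3 (0.48 log units; beyond the scatter). The smaller of the measured steps is a 2.5-fold lower number from compound 1 to compound 2 (0.41 log units; beyond the scatter). Compound 4 `O=C1c2c[n+]([O-])c3ccccc3c2C(=O)c2c1c1ccccc1n2CCCCn1ccnc1` differs from compound 3 as follows: 1H-imidazol-1-yl in place of 4-methylpiperazin-1-yl on a saturated chain carbon, four bonds along the chain from an aromatic nitrogen. Within the data shown here, no measured step covers this change; the three measured steps only swap one saturated amine group for another, and all of them were modest. The account therefore expects a modest rise for compound 4, that is a 3.8-fold higher number from compound 3 to compound 4 (0.57 log units; beyond the scatter), with wide uncertainty. Compound 4 is estimated at 300 nM, within 80 nM to 1200 nM.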

Compound 4, half-maximal inhibitory concentration: 150 nM
Compound 4: the middle estimate sits 2.0-fold (0.30 log units) above what was measured, and the stated range covers the measured number.
By their numbers in this assay, from the lowest: compounds 3, 4 and 2 (each within the scatter of the next, the first and the last beyond it); then compound 1.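

Replacing a saturated amine group with the aromatic 1H-imidazol-1-yl at this place keeps the number among those of the saturated groups in this assay: the change gives a 1.9-fold higher number from compound 3 to compound 4 (0.27 log units; within the scatter) and a 1.6-fold lower number from compound 2 to compound 4 (0.20 log units; within the scatter), so compound 4 cannot be told apart from either compound. Only the piperidin-1-yl compound stands clearly apart, with a 4.1-fold lower number from compound 1 to compound 4 (0.61 log units; beyond the scatter). Nothing available explains these steps. Still open, from the compounds shown here alone, is how another aromatic ring, such as 1H-1,2,4-triazol-1-yl, or a morpholin-4-yl group would read here, and whether a longer chain would shift the imidazole compound's number.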